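Dropping one chloro from a dichloro purine-like core

The source may report more compounds than this note shows. Statements on the series, on what has been measured and on what is new or still open speak of the compounds shown alone.

This piece follows the step from compound 1 to compound 4 in a functional assay on SNB-75 cells (Homo sapiens) for cytotoxicity, read by sulforhodamine B assay, with a stated time of 48 h; a higher number here means a weaker inhibitor of growth, a lower number a stronger inhibitor of growth. Compound 1 is `ClCc1cccc(Cn2cnc3c(Cl)nc(Cl)nc32)c1` and in this assay gives 2040 nM. Compound 3 is `ClCc1cccc(Cn2cnc3ncnc(Cl)c32)c1` and in this assay gives 1860 nM; compound 1 and compound 3 lie within the usual scatter of each other, so no order between them can be read from the numbers. Compound 2 is `ClCc1ccc(Cn2cnc3ncnc(Cl)c32)cc1`; its result in this assay is "not determined" (no result reported). Among the two numbers available, compound 1 carries the higher one, but only by a margin that means nothing.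

Compound 4 is `ClCc1cccc(Cn2cnc3c(Cl)ncnc32)c1`. It differs from compound 1 in one place: hydrogen in place of chloro on an aromatic carbon. The change removes a chloro group from an aromatic carbon that sits between two ring nitrogen atoms in the shared core, leaving a hydrogen there.

Among the measured compounds shown here, no pair of measured compounds shows this exact change, so the size of the step rests on expectation alone. Compound 4 is expected to stay close to compound 1, with a step from a 1.2-fold higher number from compound 1 to compound 4 (0.09 log units; within the scatter) that should not exceed the scatter. The estimate for compound 4 in this assay is 2500 nM, with a range from 1000 nM to 6500 nM.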

Compound 4, concentration for 50% growth inhibition: 2080 nM
Compound 4: the middle estimate sits 1.2-fold (0.08 log units) above what was measured; the measured number falls inside the stated range.
By their numbers in this assay, from the lowest: compounds 3, 1 and 4 (each within the scatter of the next).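

In this assay, among the compounds shown here, the step of a 1.0-fold higher number from compound 1 to compound 4 (0.01 log units; within the scatter) gives the first direct reading of this position, and it shows that swapping the chloro between two ring nitrogen atoms for hydrogen leaves no change the numbers can detect. For this single pair, then, growth inhibition stays at the level of compound 1 without that chloro, while the other chloro on the shared core remains in place. Nothing measured here offers a reason for this result.

From the compounds shown here alone, only chloro and hydrogen are seen at this position, so whether an amine, a methoxy group or a longer chain there would move the number remains open. Also open, going by these compounds, is whether the same swap would leave the number unmoved if the other chloro on the core were gone.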